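The source may report more compounds than this note shows. Statements on the series, on what has been measured and on what is new or still open speak of the compounds shown alone.

Compound 2 `COc1cc(C(=O)N2CCC(O)C(C)C2)cc2nc(NCc3ccnc(Cl)c3)oc12` gives 6900 nM in an assay on isolated protein for inhibition of thyroid hormone receptor beta (Homo sapiens), read by fluorescence, with a stated time of 30 min (on this read-out lower numbers stand for stronger inhibition and higher numbers for weaker inhibition), the highest of the two numbers obtained so far; its nearest neighbour, compound 1 `CCCN(CC1CCOC1)C(=O)c1cc(C)c2oc(NCc3cccc(Cl)c3)nc2c1`, gives 35 nM in this assay, a gap well beyond the scatter. Compound 3 `COc1cc(C(=O)N2CCC(O)C(C)C2)cc2nc(NCc3cc(Cl)ccc3O)oc12` has not yet been measured. It differs from compound 2 by 5-chloro-2-hydroxyphenyl in place of 2-chloropyridin-4-yl on a saturated chain carbon bound to a nitrogen on an aromatic ring. Among the measured compounds shown here, no pair of measured compounds shows this change on its own, so the direction rests on judgement alone. Compound 3 is expected to give a lower number than compound 2, with a 3.5-fold lower number from compound 2 to compound 3 (0.54 log units; beyond the scatter) estimated to reach beyond the scatter. The estimate for compound 3 is 2000 nM, with a range from 400 nM to 10000 nM.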

Compound 3, half-maximal inhibitory concentration: 170 nM
The estimate for compound 3 lay 12-fold (1.07 log units) above the measured number; measured number below the stated range.
By their numbers in this assay, from the lowest: compound 1; then compound 3; then compound 2.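

At the position on a saturated chain carbon bound to a nitrogen on an aromatic ring, the choice of ring matters strongly in this assay: 5-chloro-2-hydroxyphenyl in place of 2-chloropyridin-4-yl gives a 41-fold lower number from compound 2 to compound 3 (1.61 log units; beyond the scatter) as a large step. The change replaces a ring with a hetero atom by a ring of carbon only and also brings in a hydrogen-bond donor, so both differences sit in this one step. Nothing measured here speaks to the reason for the step.

On these data alone, whether the hydroxyl or the carbon-only ring carries the step stays open. So does what a methoxy group in place of that hydroxyl would give.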